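A Tertiary Amide in Place of the Pyridylmethyl Amide

This account rests on a few compounds, and the source may have more. Where it says the series, first, only, none or still open, it means among the compounds named here.

Compound 3 `COc1ccc(-c2oc3c(OC)c(OC)cc(OCCCCC(=O)NCc4ccccn4)c3c(=O)c2O)cc1` is the starting point of this account. In a functional assay on A549 cells (Homo sapiens) for antiproliferative activity, read by sulforhodamine B assay, with a stated time of 48 h (on this read-out lower numbers stand for stronger inhibition and higher numbers for weaker inhibition), compound 3 gives > 40000 nM, which is a limit of the assay and not a number. Two neighbours share that outcome. Compound 1 `COc1ccc(-c2oc3c(OC)c(OC)cc(OCCCC(=O)NCc4ccccn4)c3c(=O)c2O)cc1` gives > 40000 nM in this assay, again a limit. Compound 2 `COc1ccc(-c2oc3c(OC)c(OC)cc(OCCCC(=O)N4CCN(C)CC4)c3c(=O)c2O)cc1` gives > 40000 nM in this assay, also a limit. Since every value shown sits at the limit of > 40000 nM in this assay, at which 3 of the 3 values shown sit, the steps a step that the two limits leave unreadable from compound 1 to compound 2, a step that the two limits leave unreadable from compound 1 to compound 3 and a step that the two limits leave unreadable from compound 2 to compound 3 stay unreadable, and none of them tells how large a change in the amide end of the chain can be.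

Compound 4 `CCCCCN(C)C(=O)CCCCCOc1cc(OC)c(OC)c2oc(-c3ccc(OC)cc3)c(O)c(=O)c12` differs from compound 3 by (methyl(pentyl)carbamoyl)methyl in place of ((pyridin-2-yl)methyl)carbamoyl on a saturated chain carbon, four bonds along the chain from an oxygen on an aromatic ring. Going by the values given here, no measured step bears on this change with a readable size, so the only footing is that compound 3 itself sits at the limit. Compound 4 is therefore expected to give about 40000 nM in this assay, with a range from 12000 nM to 120000 nM. The expected step from compound 3 is a number no higher from compound 3 to compound 4 (the limit leaves the size open), meaning no change beyond the scatter, with a fair chance that only a limit is reported again.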

Compound 4, half-maximal inhibitory concentration: 17200 nM
The estimate for compound 4 lay 2.3-fold (0.37 log units) above the measured number; low and high end bracket the measured number.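

Replacing the ((pyridin-2-yl)methyl)carbamoyl group with (methyl(pentyl)carbamoyl)methyl gives, in this assay, an at least 2.3-fold lower number from compound 3 to compound 4 (0.36 log units; beyond the scatter). Going by these compounds alone, the steps among the three earlier compounds cannot be read, so this is the first sign that the amide end of the chain can change the result at all. The other two steps are an at least 2.3-fold lower number from compound 2 to compound 4 (0.36 log units; beyond the scatter) and an at least 2.3-fold lower number from compound 1 to compound 4 (0.36 log units; beyond the scatter), and all three give only the smallest possible size: the limit of > 40000 nM in this assay, at which 3 of the 4 values shown sit.

The change removes the pyridine ring and the amide hydrogen together, so the compounds shown cannot separate the two, nor can they show how much the pentyl chain itself contributes. Also open, as far as these compounds go, is whether a carboxylic acid, a primary amine or a longer alkyl chain at this end would give a lower number.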